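Fluoro in place of hydrogen on compound 1

The source may hold more compounds than are shown below. What is called first, only, known or untested is meant among the compounds shown, and "the series" means these compounds.

compound 1 `O=C1[C@@H](NS(=O)(=O)c2ccc3c(Cl)c[nH]c3c2)CCN1c1ccc2c(c1)CCNC2` gives 2.9 L/kg
compound 2 `O=C1[C@@H](NS(=O)(=O)c2ccc3cc[nH]c3c2)CCN1c1ccc2c(c1)CCNC2` gives 4.1 L/kg
compound 3 `O=C1[C@@H](NS(=O)(=O)c2ccc3c(Cl)c[nH]c3c2)CCN1c1ccc2c(c1F)CCNC2` gives 1.5 L/kg

In an in vivo ADME assay on the whole organism (strain Sprague-Dawley) for pharmacokinetics, with Rattus norvegicus as the target (on this read-out lower numbers stand for narrower distribution and higher numbers for wider distribution into tissues), compound 1 sits inside the range of these three values, and both of its measured steps lie within the scatter. Compound 4 `O=C1[C@@H](NS(=O)(=O)c2ccc3c(Cl)c[nH]c3c2)CCN1c1cc2c(cc1F)CNCC2` differs from it by fluoro in place of hydrogen on an aromatic carbon, ortho to a large group. Among the measured compounds shown here, the closest precedent is the same kind of swap in compound 3, a 1.9-fold lower number from compound 1 to compound 3 (0.29 log units; within the scatter), also within the scatter. The step of a 1.4-fold higher number from compound 1 to compound 2 (0.15 log units; within the scatter) concerns chloro and bears less on this change. A small downward move, not beyond the scatter, is therefore expected, with an estimated 1.3-fold lower number from compound 1 to compound 4 (0.12 log units; within the scatter) in this assay. The estimated value for compound 4 is 2.2 L/kg (expected range 1.3 L/kg to 3.7 L/kg).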

Compound 4, volume of distribution at steady state: 0.5 L/kg
Beside the measured number, compound 4's estimate is 4.4-fold (0.64 log units) above it, and the stated range ends above it.
By their numbers in this assay, from the lowest: compound 4; then compounds 3, 1 and 2 (each within the scatter of the next, the first and the last beyond it).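

In this assay, among the compounds shown here, fluoro in place of hydrogen on an aromatic carbon, ortho to a large group, gives a 5.8-fold lower number from compound 1 to compound 4 (0.76 log units; beyond the scatter), the first single swap here to pass the scatter. The same kind of swap gives only a 1.9-fold lower number from compound 1 to compound 3 (0.29 log units; within the scatter), so among these compounds a fluoro does not bring one fixed size of step. No data here account for the larger step. Open, going by these compounds, is whether a nitrile or methoxy on this aromatic carbon moves the number as far. Also open, on these data alone, is whether the step persists without the chloro.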